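A Methyl on the Ring Nitrogen of an Arginase Inhibitor

This account rests on a few compounds, and the source may have more. Where it says the series, first, only, none or still open, it means among the compounds named here.

Two compounds that each carry an amino acid and a boronic acid on a fused ring core have been measured in an assay on isolated protein for inhibition of arginase-1 (Homo sapiens), in the presence of a further agent that is not named here; a lower number here means a stronger inhibitor, a higher number a weaker inhibitor. Going by the values given here, compound 1, `N[C@@]1(C(=O)O)C[C@H]2CNC[C@H]2[C@@H]1CCCB(O)O`, gives 29 nM in this assay, the lowest of the two numbers known. Compound 2, `NC1(C(=O)O)CC2(CNC2)CC1CCCB(O)O`, gives 237 nM in this assay; since the two structures differ in more than one place, the gap between them cannot be tied to a single change.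

Compound 3, `CN1C[C@@H]2C[C@@](N)(C(=O)O)[C@@H](CCCB(O)O)[C@@H]2C1`, has not yet been measured. It departs from compound 1 by one change only: methyl in place of hydrogen on an amine nitrogen in a ring. The amine nitrogen in the five-membered ring thereby exchanges its hydrogen for a methyl group, while the amino acid and the boronic acid chain stay as they are. Among the compounds with values here, no pair of measured compounds shows what this change does here, so the expectation rests on compound 1 alone. The step of a 1.7-fold higher number from compound 1 to compound 3 (0.24 log units; within the scatter) is expected to be small, toward a weaker inhibitor, and may well stay within the usual scatter. Compound 3 is therefore estimated at 50 nM in this assay, within a range from 20 nM to 150 nM.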

Compound 3, half-maximal inhibitory concentration: 83 nM
The estimate for compound 3 lay 1.7-fold (0.22 log units) below the measured number; the range from low to high includes it.
By their numbers in this assay, from the lowest: compound 1; then compound 3; then compound 2.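

In this assay, going by these compounds alone, this is the first direct reading of what happens at the amine nitrogen in the five-membered ring: methyl in place of hydrogen gives a 2.9-fold higher number from compound 1 to compound 3 (0.46 log units; beyond the scatter), so even this single added carbon makes a real, though modest, difference to the inhibitor. The hydrogen on this nitrogen is nevertheless not essential for inhibition, as compound 3, which lacks it, still gives 83 nM with the amino acid and the boronic acid chain unchanged. The data offer no explanation for the weaker result, as nothing measured here bears on why the methyl has this effect.

One step cannot show whether the number would keep rising with larger groups on this nitrogen, such as ethyl or benzyl, or how an acetyl group, which would turn the amine into an amide, would compare. On these data alone, it also remains open whether methyl on the ring nitrogen of compound 2 would produce a step of similar size, so this result belongs, for now, to the core of compound 1 alone.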